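The source may hold more compounds than are shown below. What is called first, only, known or untested is meant among the compounds shown, and "the series" means these compounds.

For the measured compounds named here, compound 3 `CCn1nc(Cc2ccc(OC)c(OC)c2)c2ccccc2c1=O` is the only member of this small set with an actual number in a functional assay on aorta with Alpha-1D adrenergic receptor (Rattus norvegicus) as the target (on this read-out lower numbers stand for an effect already at smaller amounts and higher numbers for an effect only at larger amounts of compound), where compound 3 gives 5300 nM. Compound 1 `COc1ccc(Cc2nn(-c3ccc(Br)cc3)c(=O)c3ccccc23)cc1OC` reaches only the assay limit > 100000 nM in this assay. Compound 2 `COc1ccc(Cc2nn(-c3ccc([N+](=O)[O-])cc3)c(=O)c3ccccc23)cc1OC` likewise stops at the limit > 100000 nM. The two measured steps, an at least 18-fold lower number from compound 1 to compound 3 (1.27 log units; beyond the scatter) and an at least 18-fold lower number from compound 2 to compound 3 (1.27 log units; beyond the scatter), both replace the group on the aromatic nitrogen with ethyl. Compound 4 `C=CCn1nc(Cc2ccc(OC)c(OC)c2)c2ccccc2c1=O` keeps a short chain on that nitrogen: the change is vinyl in place of methyl on a saturated chain carbon bound to an aromatic nitrogen, which cut one bond further out reads ethyl to allyl. Going by the values given here, no measured step varies the chain itself, so for compound 4 a step within the scatter is expected, a 1.1-fold lower number from compound 3 to compound 4 (0.03 log units; within the scatter). Compound 4 is therefore estimated at 5000 nM, between 2000 nM and 15000 nM.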

Compound 4, half-maximal effective concentration: 9800 nM
The estimate for compound 4 lay 2.0-fold (0.29 log units) below the measured number, within the range that was stated.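

For the compounds shown here, on that aromatic nitrogen, ethyl to allyl is a 1.8-fold higher number from compound 3 to compound 4 (0.27 log units; within the scatter), so a second short chain reads alike there, which the earlier compounds could not show. Allyl in place of the aryl groups repeats what ethyl did, with an at least 10-fold lower number from compound 2 to compound 4 (1.00 log units; beyond the scatter) and an at least 10-fold lower number from compound 1 to compound 4 (1.00 log units; beyond the scatter). Both steps are bounded on one side only, since compound 1 and compound 2 stand at a limit: the limit of > 100000 nM in this assay, at which 2 of the 4 values shown sit.

Going by these compounds, how a longer chain, such as butyl, or an amine at the end of that chain would read in this assay remains open. So does a carboxylic acid there.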